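The compounds below may be only part of what the source reports. "The series", "measured", "known", "first", "only" and "open" are said of these compounds alone.

In a functional assay on A549 cells (Homo sapiens) for antiproliferative activity, read by MTT assay (a higher number here means a weaker inhibitor, a lower number a stronger inhibitor), compound 1 `COc1cc2c(Oc3ccc(NC(=O)Nc4ccccc4)cc3)ccnc2cc1OCCCCCCC(=O)NO` gives 1650 nM and compound 2 `COc1cc2c(Oc3ccc(NC(=O)Nc4ccccc4Cl)cc3)ccnc2cc1OCCCCCCC(=O)NO` gives 1910 nM. Among the compounds with values here, these are the only two numbers so far, and they lie within the scatter of each other, so compound 2 cannot be placed clearly apart from compound 1. Compound 3 `COc1cc2c(Oc3ccc(NC(=O)Nc4cccc(C)c4)cc3)ccnc2cc1OCCCCCCC(=O)NO` has not yet been measured. It carries 3-methylphenyl in place of 2-chlorophenyl on an amide-type nitrogen. Within the data shown here, the one measured step that bears on this change, a 1.2-fold higher number from compound 1 to compound 2 (0.06 log units; within the scatter), is chloro in place of hydrogen on an aromatic carbon, in the same phenyl group. Among the measured compounds shown here, no measured step involves a methyl group, so this evidence is indirect. For the measured compounds named here, with so small a step as the only guide, no change beyond the scatter is expected in this assay, in either direction. The expected step is a 1.1-fold lower number from compound 2 to compound 3 (0.04 log units; within the scatter). Compound 3 is estimated at 1750 nM, with an expected range of 900 nM to 3400 nM.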

Compound 3, half-maximal inhibitory concentration: 2010 nM
Compound 3: the middle estimate sits 1.1-fold (0.06 log units) below what was measured; the measured number falls inside the stated range.
By their numbers in this assay, from the lowest: compounds 1, 2 and 3 (each within the scatter of the next).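

In this assay, 3-methylphenyl in place of 2-chlorophenyl on the amide-type nitrogen gives a 1.1-fold higher number from compound 2 to compound 3 (0.02 log units; within the scatter), and adding only the methyl group gives a 1.2-fold higher number from compound 1 to compound 3 (0.09 log units; within the scatter). This phenyl group has now carried a chloro group, as 2-chlorophenyl, and a methyl group, as 3-methylphenyl, and neither step leaves the scatter, so the three compounds shown cannot be told apart in this assay. Nothing available accounts for the size of these steps.

The compounds shown leave open whether an amine, a carboxylic acid or a methoxy group on this phenyl group would also stay within the scatter, and whether 3-chlorophenyl or 2-methylphenyl would read the same. They also leave open what a longer chain on the shared core would do.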